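The source may report more compounds than this note shows. Statements on the series, on what has been measured and on what is new or still open speak of the compounds shown alone.

Measured compounds in an assay on HEK293 cells for displacement of a labelled ligand from 5-hydroxytryptamine receptor 6 (Homo sapiens), read by scintillation counting; on this read-out lower numbers stand for stronger inhibition and higher numbers for weaker inhibition:
Compound 1, `O=S(=O)(c1cncc2ccccc12)n1cc(C2=CCNCC2)c2ccccc21`: compound 1 gives 5 nM.
Compound 2, `COc1ccc2c(c1)c(C1=CCNCC1)cn2S(=O)(=O)c1cc2ccccc2cn1`: compound 2 gives 6 nM.
Compound 3, `COc1ccc2c(c1)c(C1=CCNCC1)cn2S(=O)(=O)c1cncc2ccccc12`: compound 3 gives 3 nM.

Compound 3 gives the smallest of the three numbers, but neither gap reaches beyond the scatter: a 1.7-fold lower number from compound 1 to compound 3 (0.22 log units; within the scatter) and a 2.0-fold lower number from compound 2 to compound 3 (0.30 log units; within the scatter). The two changes covered so far, the methoxy on the shared core and the swap of isoquinoline attachment at the sulfonyl sulfur, therefore both read as flat.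

The next compound, compound 4, `COc1ccc2c(c1)c(C1CCNCC1)cn2S(=O)(=O)c1cncc2ccccc12`, differs from compound 3 in one place: a group of 6 heavy atoms (5 carbon, 1 nitrogen; one six-membered non-aromatic ring with 1 hetero atom) in place of a group of 6 heavy atoms (5 carbon, 1 nitrogen; one six-membered non-aromatic ring with 1 hetero atom), on an aromatic carbon. Going by the values given here, no measured step touches this part of the molecule; the saturation of the six-membered ring bearing the basic nitrogen is untested. The two measured steps only show that the core tolerates small changes elsewhere without movement beyond the scatter. On that basis the most defensible expectation in this assay is a step of at most modest size, leaning toward a somewhat higher number. Compound 4 is expected to give 7 nM, with a range from 2 nM to 25 nM. This estimate corresponds to an expected step of a 2.3-fold higher number from compound 3 to compound 4 (0.37 log units; beyond the scatter).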

Compound 4, inhibition constant: 24 nM
The estimate for compound 4 lay 3.4-fold (0.54 log units) below the measured number; the range from low to high includes it.
By their numbers in this assay, from the lowest: compounds 3, 1 and 2 (each within the scatter of the next); then compound 4.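

In this assay, going by these compounds alone, the group on this aromatic carbon is the first place where a single change moves the number beyond the scatter: piperidin-4-yl in place of the unsaturated ring gives an 8.0-fold higher number from compound 3 to compound 4 (0.90 log units; beyond the scatter) and so marks a clear loss. The two groups match in heavy atoms, ring size, and hydrogen-bond donors and acceptors, and differ in the one double bond outside aromatic rings, so that double bond is the only computed difference tied to this step. No supporting data explain why this step occurs.

The compounds shown carry piperidin-4-yl on only one background, so it remains open whether the step has the same size without the methoxy or with isoquinolin-3-yl on the sulfonyl sulfur. As far as these compounds go, how a smaller pyrrolidin-3-yl ring or a methyl group on the ring nitrogen would read at this position also remains open.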